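A few compounds are considered here, and "the series" means these few. Any claim that something is new, unique, unknown or untested is made for them only; others in the source may bear on it.

Three compounds have so far been tested in a functional assay on PC-3 cells (Homo sapiens) for cytotoxicity, read by resazurin assay, with a stated time of 48 h; a higher number here means a weaker inhibitor, a lower number a stronger inhibitor:

Compound 1 `C=CCOC(=O)NC[C@H]1OC(N(CC2=CC[C@@H](C(=C)C)CC2)OC)[C@H](O)[C@@H](O)[C@@H]1O`: 232000 nM
Compound 2 `C=C(C)[C@@H]1CC=C(CN(OC)C2O[C@@H](CO)[C@H](N=[N+]=[N-])[C@@H](O)[C@@H]2O)CC1`: 263000 nM
Compound 3 `C=CCOC(=O)N[C@H]1C(N(CC2=CC[C@@H](C(=C)C)CC2)OC)O[C@H](CO)[C@@H](O)[C@@H]1O`: 826000 nM

All three numbers are very high, so none of the compounds is a strong inhibitor in this assay. Compound 1 has the lowest number of the three. Its gap to compound 2 lies within the usual scatter, so the two cannot be told apart; its gap to compound 3 lies beyond the scatter.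

Compound 4 `C=C(C)[C@@H]1CC=C(CN(OC)C2OC[C@@H](O)[C@H](O)[C@H]2O)CC1` differs from compound 1 in one place: hydrogen in place of ((allyloxycarbonyl)amino)methyl on a saturated ring carbon. Among the compounds with values here, no pair of measured compounds shows a step of this kind, so the expectation rests only on the general weakness of the series. For compound 4 a step of a 1.7-fold higher number from compound 1 to compound 4 (0.24 log units; within the scatter) toward a somewhat higher number is expected, likely near the edge of the scatter. The estimate for compound 4 is 400000 nM, in a range from 150000 nM to 1200000 nM.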

Compound 4, half-maximal inhibitory concentration: 152000 nM
Beside the measured number, compound 4's estimate is 2.6-fold (0.42 log units) above it; the range from low to high includes it.
By their numbers in this assay, from the lowest: compounds 4, 1 and 2 (each within the scatter of the next); then compound 3.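

In this assay, replacing ((allyloxycarbonyl)amino)methyl with hydrogen gives a 1.5-fold lower number from compound 1 to compound 4 (0.18 log units; within the scatter) and this step lies within the scatter, so compound 1 and compound 4 cannot be told apart. On this saturated ring carbon next to the ring oxygen, the whole group can therefore be removed with no measurable change in the number, which stays very high. No measured evidence accounts for this result.

As far as these compounds go, it remains open whether a carboxylic acid or an amine at this place would move the number beyond the scatter.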